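A few compounds are considered here, and "the series" means these few. Any claim that something is new, unique, unknown or untested is made for them only; others in the source may bear on it.

Compound 2 `CCN(CC)Cc1c[nH]c2ccc(F)cc12` has the lowest number of the three compounds measured in an assay on urine for inhibition of Myeloperoxidase (Homo sapiens); a lower number here means a stronger inhibitor, a higher number a weaker inhibitor: compound 2 gives 200 nM. Compound 1 `NCc1c[nH]c2ccc(F)cc12` gives 900 nM, and compound 3 `CN1CCN(Cc2c[nH]c3ccc(F)cc23)CC1` gives 1000 nM; the steps from each of these to compound 2 lie beyond the scatter. Compound 4 `NCCCc1c[nH]c2ccc(F)cc12` has not yet been measured; it differs from compound 2 by 2-aminoethyl in place of diethylamino on a saturated chain carbon bound to an aromatic carbon. Among the compounds with values here, the one measured step that bears on this is a 4.5-fold lower number from compound 1 to compound 2 (0.65 log units; beyond the scatter), where a diethylamino took the place of an amino. Compound 4 reverses that: the diethylamino leaves and a 2-aminoethyl enters, so a modest rise in this assay is expected, about a 4.0-fold higher number from compound 2 to compound 4 (0.60 log units; beyond the scatter). Compound 4 is therefore estimated at 800 nM, within a range of 250 nM to 2500 nM.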

Compound 4, half-maximal inhibitory concentration: 50 nM
Beside the measured number, compound 4's estimate is 16-fold (1.20 log units) above it; measured number outside the range, below it.
By their numbers in this assay, from the lowest: compound 4; then compound 2; then compounds 1 and 3 (each within the scatter of the next).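

In this assay the 2-aminoethyl group gives a 4.0-fold lower number from compound 2 to compound 4 (0.60 log units; beyond the scatter) in place of diethylamino and an 18-fold lower number from compound 1 to compound 4 (1.26 log units; beyond the scatter) in place of amino on the saturated chain carbon. Compounds 1 and 2 alone pointed only to carbon groups on the nitrogen as a way to a lower number, but compound 4 goes lower with a longer chain and an unsubstituted amine at its end. Nothing available explains this gain.

From the compounds shown here alone, whether a still longer chain, such as 3-aminopropyl, would go lower remains open. So does whether a diethylamino group at the end of the 2-aminoethyl chain would add to the gain.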